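Fluoro in Place of Chloro in a Level Series

The source may report more compounds than this note shows. Statements on the series, on what has been measured and on what is new or still open speak of the compounds shown alone.

In a functional assay on MIA PaCa-2 cells (Homo sapiens) for inhibition, read by MTT assay (on this read-out lower numbers stand for stronger inhibition and higher numbers for weaker inhibition), compound 1 (`O=C(Nc1ccccc1)c1cc2cnc(Nc3ccc(N4CCNCC4)cn3)nc2n1C1CCCC1`) gives 2800 nM and compound 2 (`COc1ccc(NC(=O)c2cc3cnc(Nc4ccc(N5CCNCC5)cn4)nc3n2C2CCCC2)c(OC)c1`) gives 2230 nM while compound 3 (`O=C(Nc1ccccc1Cl)c1cc2cnc(Nc3ccc(N4CCNCC4)cn3)nc2n1C1CCCC1`) gives 2170 nM and so stands within the scatter of both. Compound 4 (`O=C(Nc1ccccc1F)c1cc2cnc(Nc3ccc(N4CCNCC4)cn3)nc2n1C1CCCC1`) differs from compound 3 by fluoro in place of chloro on an aromatic carbon, ortho to a large group (fluoro in place of chloro on an aromatic carbon). Going by the values given here, the closest precedent is chloro in place of hydrogen, which stays within the scatter (a 1.3-fold lower number from compound 1 to compound 3 (0.11 log units; within the scatter)), as do the two exchanges on the amide-type nitrogen (a 1.3-fold lower number from compound 1 to compound 2 (0.10 log units; within the scatter) and a 1.0-fold lower number from compound 2 to compound 3 (0.01 log units; within the scatter)). On these steps, no change beyond the scatter is expected (a 1.1-fold higher number from compound 3 to compound 4 (0.04 log units; within the scatter)). Compound 4 is estimated at 2400 nM (expected range 1300 nM to 4300 nM).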

Compound 4, half-maximal inhibitory concentration: 3670 nM
Compound 4: the middle estimate sits 1.5-fold (0.18 log units) below what was measured, within the range that was stated.
By their numbers in this assay, from the lowest: compounds 3, 2, 1 and 4 (each within the scatter of the next).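

Both a 1.7-fold higher number from compound 3 to compound 4 (0.23 log units; within the scatter) for fluoro against chloro and a 1.3-fold higher number from compound 1 to compound 4 (0.12 log units; within the scatter) for fluoro against hydrogen hold in this assay, so a second halogen on this aromatic carbon, ortho to a large group, leaves the number level. Likewise a 1.6-fold higher number from compound 2 to compound 4 (0.22 log units; within the scatter) for 2-fluorophenyl against 2,4-dimethoxyphenyl extends this flat picture to all four groups shown on the amide-type nitrogen. As far as these compounds go, whether an amine or a carboxylic acid in this place would move the number beyond the scatter remains open. Nothing at hand accounts for these steps.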